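Primary versus methyl amides in a fused-ring acrylamide series

This account rests on a few compounds, and the source may have more. Where it says the series, first, only, none or still open, it means among the compounds named here.

Measured so far:
- compound 1, `NC(=O)/C=C1\CCc2c(Cl)cc(F)cc21`: 70%; 79% (2 entries)
- compound 2, `CNC(=O)/C=C1\CCc2c(C)cc(F)cc21`: 77%

Two compounds have numbers in a functional assay on the whole organism for inhibition, with Rattus norvegicus as the target, at a dose of 20 mg/kg by the oral route; a lower number here means less inhibition, a higher number more inhibition at the dose given (going by the name of the read-out). Compound 1, `NC(=O)/C=C1\CCc2c(Cl)cc(F)cc21`, carries a primary amide and a chlorine on the ring, and in this assay compound 1 gives 70%; 79% (2 entries); its repeated entries, (the several entries of compound 1 in this assay, 70%; 79% (2 entries)), sit within the usual scatter of each other. Compound 2, `CNC(=O)/C=C1\CCc2c(C)cc(F)cc21`, carries a methylated amide and a methyl on the ring, and in this assay compound 2 gives 77%. Going by the values given here, compound 1 and compound 2 differ in two places, so the two values show only that both sit in the same region; no single-point step is known between them, and compound 2 is the only methylated amide with a number.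

Compound 3, `Cc1cc(F)cc2c1CC/C2=C\C(N)=O`, has not been measured in this assay. It differs from compound 2 in one place: hydrogen in place of methyl on an amide-type nitrogen. With no measured step of this kind in the series, the expectation rests on compound 2 alone. Compound 1, also a primary amide, gives 70%; 79% (2 entries) in this assay, which supports a primary amide sitting in the same region. For compound 3 the step of a number 2 percentage points lower from compound 2 to compound 3 (within the scatter) is expected to be none beyond the scatter. Compound 3 is therefore estimated at 75%, between 60% and 88%.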

Compound 3, a percentage reported as inhibition, in the whole organism at one dose (the size of the read-out at that dose, not a potency): 92%
The estimate for compound 3 lay 17 percentage points below the measured number; the measured number lies above the stated range.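

Notes on the amide nitrogen: in this assay, the change on the amide-type nitrogen can now be read on its own, with the rest of the structure unchanged. Hydrogen in place of methyl gives a number 15 percentage points higher from compound 2 to compound 3 (beyond the scatter) and so marks this nitrogen as a position where the read-out responds, at least in this one pair. The earlier compounds shown here could not show this, as compound 1 and compound 2 differ in two places, and the primary amide alone does not settle the number, as the ring chlorine of compound 1 stands in place of the ring methyl of compound 3 and its entries read as follows: the several entries of compound 1 in this assay, 70%; 79% (2 entries).

Open, as far as these compounds go, is what an ethyl group or a longer chain on this nitrogen would give, and what a carboxylic acid in place of the amide would give. Also open is whether the step carries over to the chlorine-bearing core of compound 1, since only one pair of this kind is shown and it is a single-dose read-out rather than a potency.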